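This account rests on a few compounds, and the source may have more. Where it says the series, first, only, none or still open, it means among the compounds named here.

Compound 1 `COc1cc(-c2nn(-c3cccc(NC(=O)Nc4ccc(Cl)c(Cl)c4)c3)cc2-c2ccncc2)ccc1Cl` carries, on an amide-type nitrogen attached to the shared core, a carbonyl bearing a (3,4-dichlorophenyl)amino group. In a functional assay on CAKI-1 cells (Homo sapiens) for inhibition, read by sulforhodamine B assay, with a stated time of 48 h (a lower number here means that less compound is tolerated, a higher number that more compound is tolerated), compound 1 gives > 50000 nM, which is a limit of the assay rather than a number. Compound 2 `COc1cc(-c2nn(-c3cccc(NC(=O)Nc4cccc(C(F)(F)F)c4)c3)cc2-c2ccncc2)ccc1Cl` gives > 50000 nM, again a limit. The step from compound 1 to compound 2 is therefore a step that the two limits leave unreadable from compound 1 to compound 2. Compound 3 `O=C(Nc1cccc(-n2cc(-c3ccncc3)c(-c3ccc(Cl)c(O)c3)n2)c1)Nc1cc(C(F)(F)F)cc(C(F)(F)F)c1` differs from both in more than one place; compound 3 gives 26500 nM. Two of the three values sit at the limit of > 50000 nM in this assay, at which 2 of the 3 values shown sit, so compound 1 stands only at that limit, with no number of its own.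

Compound 4 `COc1cc(-c2nn(-c3cccc(NC(=O)c4ccccc4)c3)cc2-c2ccncc2)ccc1Cl` differs from compound 1 by phenyl in place of (3,4-dichlorophenyl)amino on a carbonyl carbon, so that ((3,4-dichlorophenyl)carbamoyl)amino becomes benzamido. Going by the values given here, no measured step covers this change, and the one single-point step recorded is unreadable. With compound 1 sitting at the limit > 50000 nM, the estimate for compound 4 stays near that limit: compound 4 is expected to give 50000 nM, with a range from 20000 nM to 100000 nM. The expected step is a number no higher from compound 1 to compound 4 (the limit leaves the size open), not beyond the scatter.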

Compound 4, concentration lethal to 50% of the cells: > 100000 nM
Compound 4 ended at the assay's limit; the forecaster's own chance of this, stated with the estimate: 70%; middle value at least 2.0-fold (0.30 log units) from the limit.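

Compound 1, compound 2 and compound 4 all stand at limits of the assay rather than at numbers, and no new step can be read between them. Still open, going by these compounds, is how far phenyl in place of (3,4-dichlorophenyl)amino on a carbonyl carbon moves the result in this assay.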